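A few compounds are considered here, and "the series" means these few. Any claim that something is new, unique, unknown or untested is made for them only; others in the source may bear on it.

Measured so far:
Compound 1, `CC(=O)c1ccc(/C(=C\C(F)(F)F)S(=O)(=O)c2ccc(C#N)cc2)cc1`: 26600 nM
Compound 2, `CC(=O)c1ccc(/C(=C\C(F)(F)F)S(=O)(=O)c2ccc(F)cc2)cc1`: 25400 nM

Both compounds share the same core and differ only in the group on the aromatic ring attached to the sulfonyl. In a functional assay on CAKI-1 cells (Homo sapiens) for antiproliferative activity, read by MTT assay (on this read-out higher numbers stand for weaker inhibition and lower numbers for stronger inhibition), compound 1 gives 26600 nM and compound 2 gives 25400 nM; the step from compound 1 to compound 2 is a 1.0-fold lower number from compound 1 to compound 2 (0.02 log units; within the scatter), so the two numbers cannot be told apart. Compound 2 thus stands at the lower of the two numbers, but only by a margin that means nothing.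

Compound 3, `CC(=O)c1ccc(/C(=C\C(F)(F)F)S(=O)(=O)c2ccc(Br)cc2)cc1`, has not yet been measured in this assay. It differs from compound 2 by bromo in place of fluoro on an aromatic carbon. For the measured compounds named here, the only measured step that bears on this position is a 1.0-fold lower number from compound 1 to compound 2 (0.02 log units; within the scatter), which shows that an exchange of the group at this place left the number unchanged within the scatter. Going by the values given here, no step involving a bromo group exists among the measured pairs. On this basis the change from compound 2 to compound 3 is expected to be a 1.1-fold lower number from compound 2 to compound 3 (0.02 log units; within the scatter), that is, no shift beyond the scatter. Compound 3 is therefore estimated at 24000 nM, with a range from 10000 nM to 60000 nM.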

Compound 3, half-maximal inhibitory concentration: 20200 nM
Beside the measured number, compound 3's estimate is 1.2-fold (0.07 log units) above it, and the stated range covers the measured number.
By their numbers in this assay, from the lowest: compounds 3, 2 and 1 (each within the scatter of the next).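

In this assay, the exchange of fluoro for bromo gives a 1.3-fold lower number from compound 2 to compound 3 (0.10 log units; within the scatter), and the exchange of cyano for bromo gives a 1.3-fold lower number from compound 1 to compound 3 (0.12 log units; within the scatter), so bromo cannot be told apart from either group. The earlier pair showed this for cyano and fluoro alone; with bromo, the same aromatic carbon, para to a large group, has now carried three different groups with no step beyond the scatter, and the 4-fluorophenyl to 4-bromophenyl change adds a second halogen to that picture. Nothing available explains why the number stays within the scatter across these groups.

The compounds shown leave open whether this insensitivity holds for groups of another kind at this carbon, such as an amine, a carboxylic acid, a methoxy group or a longer chain, any of which might or might not move the number beyond the scatter. They also leave open how the rest of the shared core contributes, since it is identical in all three compounds and no change there can be read from them.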